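Thiourea aryl variation on the shared core: compound 3 to compound 4

The source may hold more compounds than are shown below. What is called first, only, known or untested is meant among the compounds shown, and "the series" means these compounds.

Compound 1, `CNC(=O)c1ccc(Oc2cccc(NC(=S)Nc3ccc(F)c(C(F)(F)F)c3)c2)nc1`: in a functional assay on HepG2 cells (Homo sapiens) for antiproliferative activity, read by MTT assay (on this read-out higher numbers stand for weaker inhibition and lower numbers for stronger inhibition), compound 1 gives 20200 nM.
Compound 2, `CNC(=O)c1ccc(Oc2cccc(NC(=S)Nc3ccc(C)c(C)c3)c2)nc1`: compound 2 gives > 100000 nM, a limit of the assay rather than a number.
Compound 3, `CNC(=O)c1ccc(Oc2cccc(NC(=S)Nc3ccc(Cl)cc3Cl)c2)nc1`: compound 3 gives 21600 nM.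

Compound 3 holds the highest of the two numbers; compound 1 sits nearest, within the usual scatter, so no order between them is claimed. Within the data shown here, the one measured step is an at least 4.6-fold lower number from compound 2 to compound 3 (0.66 log units; beyond the scatter), which shows that the halogenated aryl on the thiourea nitrogen gives a number where the dimethyl analogue reaches only the limit (the limit of > 100000 nM in this assay, at which 1 of the 3 values shown sits).

Compound 4, `CNC(=O)c1ccc(Oc2cccc(NC(=S)Nc3ccc(F)c(Cl)c3)c2)nc1`, is not yet measured. The change from compound 3 is 3-chloro-4-fluorophenyl in place of 2,4-dichlorophenyl on an amide-type nitrogen. Among the measured compounds shown here, no measured step covers this exact exchange. Compound 1 and compound 3, both carrying halogenated aryls, give numbers that agree with each other, and compound 4 keeps a halogenated aryl, so the expected step from compound 3 to compound 4 is a 1.0-fold higher number from compound 3 to compound 4 (0.01 log units; within the scatter), none beyond the scatter. Compound 4 is estimated at 22000 nM, with a range from 8000 nM to 60000 nM.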

Compound 4, half-maximal inhibitory concentration: > 100000 nM
Compound 4 ended at the assay's limit; the forecaster's own chance of this, stated with the estimate: 10%; at least 4.5-fold (0.65 log units) between middle value and limit.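

In this assay, a halogenated aryl on the thiourea nitrogen does not by itself give a number: 3-chloro-4-fluorophenyl in place of 2,4-dichlorophenyl gives an at least 4.6-fold higher number from compound 3 to compound 4 (0.66 log units; beyond the scatter), and chloro in place of trifluoromethyl on an aromatic carbon gives an at least 4.9-fold higher number from compound 1 to compound 4 (0.69 log units; beyond the scatter). The second exchange keeps the fluoro group and changes one aromatic substituent, so this single change at the aryl is enough to separate a measured value from a limit. Compound 4 gives > 100000 nM, a limit of the assay and not a number, and the step between compound 2 and compound 4 cannot be read: the limit of > 100000 nM in this assay, at which 2 of the 4 values shown sit.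

On these data alone, it remains open whether bromo or methoxy in place of the chloro of compound 4 would return a number in this assay. The aryl groups shown give no general rule for halogen placement.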